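Aryl amide swap on the shared core: compound 2 to compound 3

The source may hold more compounds than are shown below. What is called first, only, known or untested is meant among the compounds shown, and "the series" means these compounds.

Compound 2 `COc1ccc2c(=O)c(/C=C/C(=O)Nc3ccccc3OC)coc2c1` carries a 2-methoxyphenyl on the amide-type nitrogen. In a functional assay on A549 cells (Homo sapiens) for inhibition, read by MTT assay, with a stated time of 48 h (on this read-out lower numbers stand for stronger inhibition and higher numbers for weaker inhibition), compound 2 gives > 100000 nM, which is a limit of the assay and not a number (the limit of > 100000 nM in this assay, at which 1 of the 2 values shown sits). Compound 1 `COc1ccc2c(=O)c(/C=C/C(=O)Nc3cccc(Cl)c3)coc2c1` has a 3-chlorophenyl on that nitrogen, and in this assay compound 1 gives 470 nM. For the measured compounds named here, the one measured step, an at least 210-fold higher number from compound 1 to compound 2 (2.32 log units; beyond the scatter), runs opposite to the change considered here.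

Compound 3 `COc1ccc2c(=O)c(/C=C/C(=O)Nc3ccc(Cl)cc3)coc2c1` differs from compound 2 by 4-chlorophenyl in place of 2-methoxyphenyl on an amide-type nitrogen. The step from compound 1 to compound 2 bears on this directly, since it shows that exchanging a chlorophenyl for the 2-methoxyphenyl at this nitrogen moved the number far beyond the scatter, up to the limit. Going by the values given here, compound 3 reverses that exchange with the chlorine placed as 4-chlorophenyl rather than 3-chlorophenyl; no measured pair separates those two, so that part of the change is unanchored. A large step toward a lower number in this assay is therefore expected. Compound 3 is estimated at 1500 nM, with a range from 250 nM to 30000 nM. This amounts to an expected step of an at least 66-fold lower number from compound 2 to compound 3 (1.82 log units; beyond the scatter).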

Compound 3, half-maximal inhibitory concentration: > 100000 nM
Compound 3 was reported as a limit (the forecaster's own chance of this, stated with the estimate: 12%); at least 66-fold (1.82 log units) between middle value and limit.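

In this assay, 4-chlorophenyl in place of 3-chlorophenyl on the amide-type nitrogen gives an at least 210-fold higher number from compound 1 to compound 3 (2.32 log units; beyond the scatter), so a chlorophenyl on this nitrogen does not by itself carry the inhibition seen with compound 1. This separates the two chlorophenyl groups, a pair the earlier compounds left unanchored, and of the aryl groups shown only 3-chlorophenyl gives a value that is not a limit. The step from compound 2 to compound 3 cannot be read, since both ends are limits of the assay, and no order can be stated between 2-methoxyphenyl and 4-chlorophenyl; the limit now holds most of the series: the limit of > 100000 nM in this assay, at which 2 of the 3 values shown sit.

Open, going by these compounds, is whether the inhibition of compound 1 depends on the chlorine itself or would also appear with another group in its place, such as 3-fluorophenyl, 3-methoxyphenyl or 3-methylphenyl on the same nitrogen. Also open, on these data alone, are 2-chlorophenyl and unsubstituted phenyl on this nitrogen, which would show whether the two limits of compound 2 and compound 3 reflect the groups they carry or the general behaviour of the series, with compound 1 as the exception.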